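Compound 3: amino in place of methyl

A few compounds are considered here, and "the series" means these few. Any claim that something is new, unique, unknown or untested is made for them only; others in the source may bear on it.

Among the compounds with values here, in an ADME assay on MDCK cells (Canis lupus familiaris) for cytotoxicity, read by MTT assay, with a stated time of 24 h (a higher number here means that more compound is tolerated, a lower number that less compound is tolerated), compound 2 (`Cc1ccc(S(=O)(=O)N(CCC#N)Cc2cccs2)cc1`) gives 127000 nM, the only actual number so far. Compound 1 (`N#CCCN(Cc1cccs1)S(=O)(=O)c1cccc(F)c1`) gives > 205000 nM, which is a limit of the assay and not a number. This leaves compound 2 with no second number to be ranked against.

Compound 3 (`N#CCCN(Cc1cccs1)S(=O)(=O)c1ccc(N)cc1`) keeps the core of compound 2 and carries amino in place of methyl on an aromatic carbon, para to a large group: amino in place of methyl on an aromatic carbon.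

Within the data shown here, the only measured step is an at least 1.6-fold lower number from compound 1 to compound 2 (0.20 log units; that floor lies within the scatter). From the compounds shown here alone, it changes the group on the sulfonyl sulfur, but it is a different swap, and its true size stays open since one end is a limit: the limit of > 205000 nM in this assay, at which 1 of the 2 values shown sits. Among the measured compounds shown here, no measured step replaces methyl with amino, so the evidence for this change is thin. With the floor of the step to compound 2 (an at least 1.6-fold lower number from compound 1 to compound 2 (0.20 log units; that floor lies within the scatter)) inside the scatter, no shift beyond the scatter is expected in this assay, and no direction is favoured.

The expected change is a 1.0-fold higher number from compound 2 to compound 3 (0.01 log units; within the scatter). For compound 3 the estimated value is 130000 nM, with an expected range from 65000 nM to 260000 nM.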

Compound 3, half-maximal cytotoxic concentration: > 207000 nM
Compound 3 was reported as a limit; the forecaster's own chance of this, stated with the estimate: 25%; middle value at least 1.5-fold (0.20 log units) from the limit.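

In this assay compound 3 gives > 207000 nM, which is a limit of the assay and not a number. Within the data shown here, this is the first measured swap at this position, on an aromatic carbon para to a large group: amino in place of methyl gives an at least 1.6-fold higher number from compound 2 to compound 3 (0.21 log units; that floor lies within the scatter), so the change from 4-methylphenyl to 4-aminophenyl has a lower bound on its size, and that bound does not separate the two compounds beyond the scatter. The step linking compound 1 and compound 3 cannot be read, and compound 3 joins compound 1 at a limit, which leaves compound 2 as the only compound in the series with an actual number: the limit of > 207000 nM in this assay, at which 1 of the 3 values shown sits.

From the compounds shown here alone, the true size of the amino-for-methyl step stays open, and so does its meaning beyond the scatter, since only one end of it is a number. Also open, going by these compounds, is how a carboxylic acid, a methoxy group or a longer chain on the same aromatic carbon would read in this assay, and whether any of them would give a number rather than a limit.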